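Replacing the phenylethenyl arm with a methoxyphenyl arm

A few compounds are considered here, and "the series" means these few. Any claim that something is new, unique, unknown or untested is made for them only; others in the source may bear on it.

Of the compounds shown here, three sharing one core have been measured in a functional assay on Ehrlich cells (Mus musculus) for cytotoxicity, read by trypan blue exclusion, with a stated time of 2 h, tested at 50 ug/mL; a higher number here means a stronger effect of the compound at the concentration tested, a lower number a weaker effect. Compound 1 `N#CC1=C(N)N(c2ccc(S(N)(=O)=O)cc2)C2=C(CCCC2)C1c1ccccc1O` gives 50%, compound 2 `N#CC1=C(N)N(c2ccc(S(N)(=O)=O)cc2)C2=C(CCCC2)C1c1ccc(O)cc1` gives 60%, and compound 3 `N#CC1=C(N)N(c2ccc(S(N)(=O)=O)cc2)C2=C(CCCC2)C1/C=C/c1ccccc1` gives 90%. Compound 3 stands highest of the three numbers; its nearest neighbour is compound 2, and its furthest is compound 1, both beyond the scatter. Compound 4 `COc1ccc(C2C(C#N)=C(N)N(c3ccc(S(N)(=O)=O)cc3)C3=C2CCCC3)cc1` has not yet been measured. It differs from compound 3 in one place: 4-methoxyphenyl in place of 2-phenylethenyl on a saturated ring carbon.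

Among the measured compounds shown here, two measured steps bear on this change, both running toward the 2-phenylethenyl group: a number 40 percentage points higher from compound 1 to compound 3 (beyond the scatter) and a number 30 percentage points higher from compound 2 to compound 3 (beyond the scatter). The step to compound 4 runs the other way, from the 2-phenylethenyl group back to an aryl group, so a drop in this assay beyond the scatter is expected, with compound 2 as the closest measured point of reference because its value is 60%. Compound 4 is therefore estimated at 60%, within 40% to 80%. The expected step is a number 30 percentage points lower from compound 3 to compound 4 (beyond the scatter).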

Compound 4, a percentage reported as activity, at one concentration (the size of the read-out at that concentration, not a potency): 100%
The estimate for compound 4 lay 40 percentage points below the measured number; measured number outside the range, above it.
By their numbers in this assay, from the lowest: compounds 1 and 2 (each within the scatter of the next); then compounds 3 and 4 (each within the scatter of the next).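

At this saturated ring carbon, this assay does not separate the 4-methoxyphenyl group from the 2-phenylethenyl group (a number 10 percentage points higher from compound 3 to compound 4 (within the scatter)), so the lower numbers of compounds 1 and 2 do not hold for every aryl group there. Methyl in place of hydrogen on the oxygen of the 4-hydroxyphenyl group gives a number 40 percentage points higher from compound 2 to compound 4 (beyond the scatter) and the change from the 2-hydroxyphenyl group gives a number 50 percentage points higher from compound 1 to compound 4 (beyond the scatter), both much larger than the step from the 2-phenylethenyl group. Nothing available explains why these changes have these effects.

On these data alone, whether a longer ether such as ethoxy, or an amine or a carboxylic acid, on the same phenyl ring would match the methoxy group remains open. A reading at one concentration also leaves open whether compound 3 and compound 4 differ in potency.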